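The source may report more compounds than this note shows. Statements on the series, on what has been measured and on what is new or still open speak of the compounds shown alone.

Within the data shown here, in an ADME assay on BJ cells (Homo sapiens) for cytotoxicity, read by CellTiter-Glo and resazurin assay, with a stated time of 72 h (on this read-out higher numbers stand for an effect only at larger amounts of compound and lower numbers for an effect already at smaller amounts), the three compounds measured so far all sit at the limit of the assay. Compound 1 `CCOC(=O)CCCCCOc1cccc(CN(C(=O)c2ccc(-c3ccc4ccccc4c3)cc2)C(C)C)c1` gives > 26000 nM, a limit. Compound 2 `CCOC(=O)CCCCCOc1cccc(CN(C(=O)c2ccc(-c3cccc(-c4ccccc4)c3)cc2)C(C)C)c1` gives > 26000 nM, likewise a limit. Compound 3 `CCOC(=O)CCCCCOc1cccc(CN(C(=O)c2ccc(-c3cccc(OCC)c3)cc2)C(C)C)c1` gives > 22300 nM, again a limit. The steps a step that the two limits leave unreadable from compound 1 to compound 2, a step that the two limits leave unreadable from compound 1 to compound 3 and a step that the two limits leave unreadable from compound 2 to compound 3 therefore carry no readable size. Compound 4 `CCOC(=O)CCCCCOc1cccc(CN(C(=O)c2ccc(-c3cccc(OC(F)(F)F)c3)cc2)C(C)C)c1` differs from compound 3 by trifluoromethyl in place of ethyl on an oxygen on an aromatic ring. Among the measured compounds shown here, no measured step bears on this change, and the three measured values rest only at the limit of > 26000 nM in this assay, at which 2 of the 3 values shown sit, and at the limit of > 22300 nM in this assay, at which 1 of the 3 values shown sits. Compound 4 is therefore expected to sit at the limit as well, estimated at 30000 nM with a range of 15000 nM to 80000 nM. The step that the limit leaves unreadable from compound 3 to compound 4 is expected to be small.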

Compound 4, half-maximal effective concentration: > 26000 nM
Compound 4: no number, only a limit (the forecaster's own chance of this, stated with the estimate: 85%); the middle value lies beyond the limit too.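

Compound 4, like compounds 1, 2 and 3, gives only a limit in this assay, so none of its steps to those compounds can be read. The compounds shown leave open whether swapping these groups changes the effective concentration at all.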